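A few compounds are considered here, and "the series" means these few. Any claim that something is new, unique, unknown or untested is made for them only; others in the source may bear on it.

Compound 1 `COc1cc(C2=NN(C(C)=O)C(c3ccc(Cl)cc3)C2)cc(OC)c1OC` gives 35000 nM in a functional assay on B16 cells (Mus musculus) for cytotoxicity, read by MTT assay, with a stated time of 72 h; on this read-out lower numbers stand for stronger inhibition and higher numbers for weaker inhibition.
Compound 2 `COc1ccccc1C1CC(c2cc(OC)c(OC)c(OC)c2)=NN1C(C)=O` gives in this assay only a limit of the assay, > 100000 nM.
Compound 3 `COc1ccc(C2CC(c3cc(OC)c(OC)c(OC)c3)=NN2C(C)=O)cc1[N+](=O)[O-]` also gives in this assay only a limit of the assay, > 100000 nM.

Compound 3 therefore stands at the limit of > 100000 nM in this assay, at which 2 of the 3 values shown sit, with no number of its own. Compound 4 `COc1ccc(C2CC(c3cc(OC)c(OC)c(OC)c3)=NN2C(C)=O)cc1O` differs from compound 3 by hydroxy in place of nitro on an aromatic carbon, a hydroxy group in place of nitro on an aromatic carbon. Within the data shown here, the only measured step, an at least 2.8-fold higher number from compound 1 to compound 2 (0.45 log units; beyond the scatter), exchanged the whole aromatic ring on the saturated ring carbon and led to a limit; compound 3 shows the same kind of result as compound 2, so no measured step tracks this exact swap. No step beyond the scatter is expected in this assay, and the estimated step is a number no higher from compound 3 to compound 4 (the limit leaves the size open). Compound 4 is estimated at 100000 nM, between 30000 nM and 300000 nM, most likely again only a limit.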

Compound 4, half-maximal inhibitory concentration: > 100000 nM
Compound 4 was reported as a limit (the forecaster's own chance of this, stated with the estimate: 70%); the middle value lies on the limit itself.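

In this assay, hydroxy in place of nitro on this aromatic carbon, ortho to a methoxy group, leaves compound 4 at a limit and not at a number, as compound 3 was: the limit of > 100000 nM in this assay, at which 3 of the 4 values shown sit. The steps to compound 4 from compound 2 and from compound 3 cannot be read, as both ends of each are limits. Among these compounds, with 3-hydroxy-4-methoxyphenyl in place of 4-chlorophenyl, the one readable step is an at least 2.8-fold higher number from compound 1 to compound 4 (0.45 log units; beyond the scatter).

Whether hydroxy and nitro differ at all remains hidden behind the limit. On these data alone, whether an amine or a carboxylic acid on this aromatic carbon would give a number of its own in this assay also stays open.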